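Swapping an aryl group for furanylmethyl on a thiourea nitrogen

This account rests on a few compounds, and the source may have more. Where it says the series, first, only, none or still open, it means among the compounds named here.

Two thioureas sharing a trifluoromethylphenyl-bearing core have been measured in an ADME assay on Vero 76 cells (Chlorocebus sabaeus) for cytotoxicity, read by crystal violet staining, with a stated time of 96 h; on this read-out lower numbers stand for higher toxicity in this test and higher numbers for lower toxicity in this test. Compound 1, `Fc1ccccc1NC(=S)Nc1cccc(C(F)(F)F)c1`, gives 64000 nM and so stands at the highest number of the two. Compound 2, `O=C(NC(=S)Nc1cccc(C(F)(F)F)c1)[C@H]1C[C@@H]2CC[C@H]1C2`, gives 20000 nM, a lower number, and its gap to compound 1 lies beyond the usual scatter. Compound 3, `FC(F)(F)c1cccc(NC(=S)NCc2ccco2)c1`, has not yet been measured. It differs from compound 1 in one place: (furan-2-yl)methyl in place of 2-fluorophenyl on an amide-type nitrogen. No single change of this kind has been followed among the measured pairs, so nothing shown here fixes the size of the step. With both measured values lying at the high end of this assay, compound 3 is expected to stay near compound 1, and the step of a 1.3-fold lower number from compound 1 to compound 3 (0.11 log units; within the scatter) is expected to remain within the scatter. The estimate for compound 3 is therefore 50000 nM, with a range from 20000 nM to 150000 nM.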

Compound 3, half-maximal cytotoxic concentration: 50000 nM
Compound 3: the middle estimate sits on the measured number at the digits printed, and the stated range covers the measured number.
By their numbers in this assay, from the lowest: compound 2; then compounds 3 and 1 (each within the scatter of the next).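

In this assay, among the compounds shown here, the swap of 2-fluorophenyl for (furan-2-yl)methyl on the amide-type nitrogen gives a 1.3-fold lower number from compound 1 to compound 3 (0.11 log units; within the scatter) and is the first single swap followed at this place. The nitrogen, whose other neighbour is the thiocarbonyl carbon, thus carries a six-membered aromatic ring of carbon only or a five-membered aromatic ring with 1 hetero atom, and the two compounds cannot be told apart in this read-out. Nothing measured here accounts for this likeness.

The compounds shown leave open whether other groups on this nitrogen, such as an aminoethyl chain or a longer chain ending in a carboxylic acid, would read the same way. They also leave open how far the result rests on the furan ring and how far on its methyl link, which a benzyl group on the same nitrogen would help to separate.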